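Removing the (1-bromoethenyl)carbonyl group from compound 2

The compounds below may be only part of what the source reports. "The series", "measured", "known", "first", "only" and "open" are said of these compounds alone.

In a functional assay on L1210 cells (Mus musculus) for antiproliferative activity, with a stated time of 48 h (on this read-out higher numbers stand for weaker inhibition and lower numbers for stronger inhibition), compound 2 `C=C(Br)C(=O)Nc1ccc(/C=C/C(=O)c2ccc(Cl)c(Cl)c2)cc1` gives 2100 nM, level with compound 1 `C=C(Br)C(=O)Nc1ccc(/C=C/C(=O)c2ccc(F)cc2)cc1` at 1600 nM, while compound 3 `C=C(Br)C(=O)Nc1ccc(/C=C/C(=O)c2cccs2)cc1` gives a clearly lower 250 nM. Compound 4 `Nc1ccc(/C=C/C(=O)c2ccc(Cl)c(Cl)c2)cc1` has hydrogen in place of (1-bromoethenyl)carbonyl on a nitrogen on an aromatic ring. The measured steps, a 1.3-fold higher number from compound 1 to compound 2 (0.12 log units; within the scatter) and an 8.4-fold lower number from compound 2 to compound 3 (0.92 log units; beyond the scatter), only swap the group on a carbonyl carbon, so none tests this change. All three measured compounds keep the departing group, and losing it is a larger edit than those swaps. The expected step in this assay is a 5.7-fold higher number from compound 2 to compound 4 (0.76 log units; beyond the scatter), towards weaker inhibition. Compound 4 is estimated at 12000 nM, with an expected range from 3000 nM to 50000 nM.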

Compound 4, half-maximal inhibitory concentration: 26000 nM
The estimate for compound 4 lay 2.2-fold (0.34 log units) below the measured number; the range from low to high includes it.
By their numbers in this assay, from the lowest: compound 3; then compounds 1 and 2 (each within the scatter of the next); then compound 4.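

In this assay, replacing (1-bromoethenyl)carbonyl with hydrogen on the nitrogen gives a 12-fold higher number from compound 2 to compound 4 (1.09 log units; beyond the scatter), towards weaker inhibition. This is the first change shown at this position, and it shows that much of the activity of compound 2 depends on having this group on the nitrogen. Nothing given here explains the loss. Going by these compounds, what stays open is which part of the departing group matters: an acetyl group or a plain propenoyl group without bromine on the same nitrogen would separate the bromine and the double bond from the carbonyl. On these data alone, whether the same loss occurs with thiophen-2-yl on the carbonyl carbon also remains open.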